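The source may hold more compounds than are shown below. What is called first, only, known or untested is meant among the compounds shown, and "the series" means these compounds.

Measured so far:
compound 1 `O=C(NO)c1cccc(OCc2ccc(-c3noc(-c4ccccc4)n3)cc2)c1` — in an assay on isolated protein for inhibition of sphingomyelin phosphodiesterase (Homo sapiens), read by fluorescence, with a stated time of 30 min (a higher number here means a weaker inhibitor, a lower number a stronger inhibitor), compound 1 gives > 100000 nM, a limit of the assay.
compound 2 `O=C(NO)c1cccc(OCc2ccc(-c3noc(-c4ccc(Br)cc4)n3)cc2)c1` — compound 2 gives > 100000 nM, again a limit.
compound 3 `COc1ccc(C(=O)NO)cc1OCc1ccc(-c2noc(-c3ccccc3)n2)cc1` — compound 3 gives 15900 nM, the only number among the three.

From compound 1 to compound 2 the change is bromo in place of hydrogen on an aromatic carbon; the step that the two limits leave unreadable from compound 1 to compound 2 because both values sit at the limit of > 100000 nM in this assay, at which 2 of the 3 values shown sit. From compound 1 to compound 3 the change is methoxy in place of hydrogen on an aromatic carbon, and here the step is an at least 6.2-fold lower number from compound 1 to compound 3 (0.79 log units; beyond the scatter).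

Compound 4 `COc1ccc(C(=O)NO)cc1OCc1ccc(-c2noc(-c3ccc(Br)cc3)n2)cc1` is not yet measured. It differs from compound 3 by bromo in place of hydrogen on an aromatic carbon, the same change that leads from compound 1 to compound 2, made on the core of compound 3 rather than that of compound 1; the two cores differ by methoxy in place of hydrogen on an aromatic carbon. Since the earlier step that the two limits leave unreadable from compound 1 to compound 2, it offers no guide to the size of the step expected from compound 3 to compound 4, so compound 4 is expected to stay near compound 3, with a step of a 1.1-fold lower number from compound 3 to compound 4 (0.03 log units; within the scatter) in this assay, and its expected value is 15000 nM, estimated between 4000 nM and 60000 nM.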

Compound 4, half-maximal inhibitory concentration: > 100000 nM
Compound 4: only a limit was reported; the forecaster's own chance of this, stated with the estimate: 25%; middle value at least 6.6-fold (0.82 log units) away from the limit.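

Setting bromo in place of hydrogen on the core of compound 3 gives an at least 6.2-fold higher number from compound 3 to compound 4 (0.79 log units; beyond the scatter) in this assay, so on this core the change from phenyl to 4-bromophenyl weakens inhibition. Compound 4 gives > 100000 nM, which is a limit and not a number. The steps from compound 1 to compound 2 and from compound 2 to compound 4 cannot be read, so the series does not show whether the change acts alike on the two cores, because these values all sit at the same limit: the limit of > 100000 nM in this assay, at which 3 of the 4 values shown sit.

On these data alone, it remains open whether the weakening belongs to bromo alone, or whether fluoro, methyl or an amine in its place on the phenyl ring would give the same result on the core of compound 3. Also open, as far as these compounds go, is whether a longer chain in place of the methoxy group would strengthen inhibition further on either core.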